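Propoxy to trifluoromethoxy on the aryl sulfonamide

The source may hold more compounds than are shown below. What is called first, only, known or untested is meant among the compounds shown, and "the series" means these compounds.

Measured compounds:
compound 1 `CCCOc1ccc(S(=O)(=O)N2CCC(N3CCC(C)CC3)CC2)cc1` — 452 nM
compound 2 `CC1CCN(C2CCN(S(=O)(=O)c3sc(Cl)nc3C3CC3)CC2)CC1` — > 5000 nM
compound 3 `CC1CCN(C2CCN(S(=O)(=O)c3cccc(-c4ccccc4)c3)CC2)CC1` — 2 nM

Of the compounds shown here, three sharing the piperidinyl-piperidine sulfonamide core have been measured in a functional assay on DLD-1 cells (Homo sapiens) for antiproliferative activity, read by CellTiter-Glo, with a stated time of 72 h; a higher number here means a weaker inhibitor, a lower number a stronger inhibitor. Compound 1 gives 452 nM, the highest of the two numbers reported. Compound 3 gives 2 nM, a much lower number than compound 1, and the gap between the two lies beyond the scatter. For compound 2 this assay reports only a limit, > 5000 nM, and not a number (the limit of > 5000 nM in this assay, at which 1 of the 3 values shown sits).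

Compound 4 `CC1CCN(C2CCN(S(=O)(=O)c3ccc(OC(F)(F)F)cc3)CC2)CC1` is the unmeasured compound that follows compound 1. The change is trifluoromethyl in place of propyl on an oxygen on an aromatic ring, read one bond further out as propoxy to trifluoromethoxy. No measured pair shows this change, so its effect in this assay is not known from the data shown. The two groups are close in heavy-atom count, and no step beyond the scatter is expected in either direction; a step of a 1.1-fold lower number from compound 1 to compound 4 (0.05 log units; within the scatter) is estimated. Compound 4 is expected to give about 400 nM, within a range from 100 nM to 1600 nM.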

Compound 4, half-maximal inhibitory concentration: 16 nM
Beside the measured number, compound 4's estimate is 25-fold (1.40 log units) above it, outside the stated range (below it).
By their numbers in this assay, from the lowest: compound 3; then compound 4; then compound 1. At a limit, above all of these: compound 2.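

In this assay the change from propyl to trifluoromethyl on the oxygen on the aromatic ring gives a 28-fold lower number from compound 1 to compound 4 (1.45 log units; beyond the scatter) and so provides the first measured pair among these compounds. It shows that the number at this place depends strongly on the group carried by the oxygen, even though both groups have no ring, no hydrogen-bond donors or acceptors and no net charge. The data shown give no measured property that bears on the size of this step.

From the compounds shown here alone, what remains open is whether a methyl, ethyl or difluoromethyl group on the same oxygen would give a number closer to that of compound 1 or of compound 4. Also open, going by these compounds, is how a longer chain or an amine would behave in that place.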